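The source may report more compounds than this note shows. Statements on the series, on what has been measured and on what is new or still open speak of the compounds shown alone.

Within the data shown here, in a functional assay on HL-60 cells (Homo sapiens) for antiproliferative activity, read by MTT assay, with a stated time of 48 h (on this read-out lower numbers stand for stronger inhibition and higher numbers for weaker inhibition), compound 1 `CC(C)=CCC[C@]1(C)/C=C/[C@@H](OC(=O)C=C(C)C)[C@](C)(O)/C=C/C(=O)/C(CN(C)C)=C\C1` gives 140 nM, the lowest number among the three compounds tested so far. Compound 2 `CC(C)=CCC[C@]1(C)/C=C/[C@@H](OC(=O)C=C(C)C)[C@](C)(O)/C=C/C(=O)/C(C[Si](c2ccccc2)(c2ccccc2)C(C)(C)C)=C\C1` gives 14400 nM, a gap from the first result that lies well beyond the scatter. Compound 3 `CC(C)=CCC[C@]1(C)/C=C/[C@@H](OC(=O)C=C(C)C)[C@](C)(O)CCC(=O)/C(CO)=C\C1` reaches only a limit of the assay, > 40000 nM.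

Compound 4 `COCOC/C1=C/C[C@](C)(CCC=C(C)C)/C=C/[C@@H](OC(=O)C=C(C)C)[C@](C)(O)/C=C/C1=O` has not yet been measured. It keeps the core of compound 1 and differs from it in one place: methoxymethoxy in place of dimethylamino on a saturated chain carbon bound to a double-bonded ring carbon. In words, methoxymethoxy stands in place of dimethylamino on a saturated chain carbon bound to a double-bonded ring carbon. Compound 2 also lacks the dimethylamino group and reads 14400 nM, so a large rise beyond the scatter, towards weaker inhibition, is expected in this assay. The expected change is a 36-fold higher number from compound 1 to compound 4 (1.55 log units; beyond the scatter). For compound 4, the estimated value is 5000 nM, with an expected range from 800 nM to 30000 nM.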

Compound 4, half-maximal inhibitory concentration: 2840 nM
Beside the measured number, compound 4's estimate is 1.8-fold (0.25 log units) above it; low and high end bracket the measured number.
By their numbers in this assay, from the lowest: compound 1; then compound 4; then compound 2. At a limit, above all of these: compound 3.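

Read in this assay, the change from dimethylamino to methoxymethoxy on a saturated chain carbon bound to a double-bonded ring carbon gives a 20-fold higher number from compound 1 to compound 4 (1.31 log units; beyond the scatter) with the rest of the molecule unchanged, so this is the first direct reading of what this place contributes. It shows that the group here alone moves the read-out by a large margin towards weaker inhibition. Even so, compound 4 at 2840 nM still gives a measured number and not a limit, so replacing dimethylamino with methoxymethoxy weakens inhibition without removing it. Nothing shown explains the size of this step.

The compounds shown leave open how a primary amine, a morpholine or a plain methoxy group would read at this place. They also leave open whether the same step would hold on cells other than these.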